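Aromatic substituent steps on the indole of compound 3

The compounds below may be only part of what the source reports. "The series", "measured", "known", "first", "only" and "open" are said of these compounds alone.

Three compounds of the shared core have numbers in a functional assay on WiDr cells (Homo sapiens) for inhibition, read by sulforhodamine B assay, with a stated time of 48 h; on this read-out higher numbers stand for weaker inhibition of growth and lower numbers for stronger inhibition of growth. Compound 1 `COC(=O)[C@@]1(C)CCC=C2[C@@H]1CC[C@@H](C)[C@]2(C)Cc1c(C)[nH]c2ccccc12` gives 19000 nM. Compound 2 `COC(=O)[C@@]1(C)CCC=C2[C@@H]1CC[C@@H](C)[C@]2(C)Cc1c(C)[nH]c2ccc(C)cc12`, with methyl in place of hydrogen on an aromatic carbon, gives 28000 nM, and the step of a 1.5-fold higher number from compound 1 to compound 2 (0.17 log units; within the scatter). Compound 3 `COC(=O)[C@@]1(C)CCC=C2[C@@H]1CC[C@@H](C)[C@]2(C)Cc1c(C)[nH]c2ccc(F)cc12` gives 17000 nM; it sits at the low end of the three numbers, but a 1.1-fold lower number from compound 1 to compound 3 (0.05 log units; within the scatter) and a 1.6-fold lower number from compound 2 to compound 3 (0.22 log units; within the scatter) are both within the scatter, so the three numbers cannot be told apart.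

Compound 4 `COC(=O)[C@@]1(C)CCC=C2[C@@H]1CC[C@@H](C)[C@]2(C)Cc1c(C)[nH]c2ccc(C(F)(F)F)cc12` differs from compound 3 by trifluoromethyl in place of fluoro on an aromatic carbon. Going by the values given here, the steps that bear on this position are the three above, all within the scatter, so substitution at this aromatic carbon has so far moved this assay little. Among the compounds with values here, a trifluoromethyl group has not been tested at this position, and no step gives it a direction. The step of a 1.1-fold higher number from compound 3 to compound 4 (0.02 log units; within the scatter) is therefore expected to be small and without a clear direction. Compound 4 is estimated at 18000 nM in this assay, with a range from 7000 nM to 45000 nM.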

Compound 4, concentration for 50% growth inhibition: 21000 nM
For compound 4 the middle estimate is 1.2-fold (0.07 log units) below the measured one; low and high end bracket the measured number.
By their numbers in this assay, from the lowest: compounds 3, 1, 4 and 2 (each within the scatter of the next).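

Trifluoromethyl joins hydrogen, methyl and fluoro on this aromatic carbon, and it is the first group tested here that replaces fluoro with more than one fluorine. In this assay the new group gives a 1.2-fold higher number from compound 3 to compound 4 (0.09 log units; within the scatter), a 1.3-fold lower number from compound 2 to compound 4 (0.12 log units; within the scatter) and a 1.1-fold higher number from compound 1 to compound 4 (0.04 log units; within the scatter), so all four groups at this position remain indistinguishable, and this holds even with the larger substituent. No accompanying measurement bears on what lies behind these close numbers.

From the compounds shown here alone, it remains open whether a different kind of group on this carbon, such as an amine, a carboxylic acid or a longer chain, would give a step beyond the scatter. The compounds shown also leave open whether a change elsewhere on the shared core would move this read-out at all.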